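Swapping Fluoro for Cyano on a Benzyl Ether

This account rests on a few compounds, and the source may have more. Where it says the series, first, only, none or still open, it means among the compounds named here.

Three compounds share one core and differ only in the group carried on a saturated chain carbon bound to an oxygen on an aromatic ring. Compound 1 `COc1cc(OC)c(-c2coc3cc(OCC=C(C)C)ccc3c2=O)cc1OC` carries a 2-methylprop-1-en-1-yl group there, and in a functional assay on HepG2 cells (Homo sapiens) for antiproliferative activity, read by MTT assay, with a stated time of 24 h (on this read-out lower numbers stand for stronger inhibition and higher numbers for weaker inhibition), compound 1 gives 280 nM. Compound 2 `COc1cc(OC)c(-c2coc3cc(OCC(=O)c4cccc(C(F)(F)F)c4)ccc3c2=O)cc1OC` carries a (3-(trifluoromethyl)phenyl)carbonyl group; in this assay compound 2 reaches only the limit > 10000 nM, which is a limit of the assay and not a number. Compound 3 `COc1cc(OC)c(-c2coc3cc(OCc4ccc(F)cc4)ccc3c2=O)cc1OC` carries a 4-fluorophenyl group, and compound 3 gives 1000 nM. Of the two numbers, compound 3 sits highest, with compound 1 nearest: a 3.6-fold higher number from compound 1 to compound 3 (0.55 log units; beyond the scatter). The other steps, an at least 35-fold higher number from compound 1 to compound 2 (1.55 log units; beyond the scatter) and an at least 10-fold lower number from compound 2 to compound 3 (1.00 log units; beyond the scatter), show that the group on that chain carbon can move the read-out a great deal.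

Compound 4 `COc1cc(OC)c(-c2coc3cc(OCc4ccc(C#N)cc4)ccc3c2=O)cc1OC` differs from compound 3 in a single way: cyano in place of fluoro on an aromatic carbon. Within the data shown here, none of the measured steps changes a substituent on a 4-fluorophenyl group; each replaces the whole group, so no measured step bears directly on this swap. For compound 4 the expected step therefore lies within the scatter, in either direction: a 1.2-fold higher number from compound 3 to compound 4 (0.08 log units; within the scatter). Compound 4 is expected to give about 1200 nM, within 400 nM to 4000 nM.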

Compound 4, half-maximal inhibitory concentration: 4230 nM
Compound 4: the middle estimate sits 3.5-fold (0.55 log units) below what was measured; measured number above the stated range.
By their numbers in this assay, from the lowest: compound 1; then compound 3; then compound 4. At a limit, above all of these: compound 2.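

Every earlier step replaced the whole group on the chain carbon, whereas in this assay this one changes only the substituent on an aromatic carbon of the benzyl ether, and it still moves the read-out beyond the scatter: a 4.2-fold higher number from compound 3 to compound 4 (0.63 log units; beyond the scatter). This aromatic carbon is therefore not a neutral place in this pair, and cyano goes with weaker inhibition than fluoro. Among the whole-group changes, the 4-cyanophenyl group gives a 15-fold higher number from compound 1 to compound 4 (1.18 log units; beyond the scatter) when set against 2-methylprop-1-en-1-yl, and an at least 2.3-fold lower number from compound 2 to compound 4 (0.37 log units; beyond the scatter) when set against (3-(trifluoromethyl)phenyl)carbonyl, a comparison whose starting entry is a limit of the assay and not a number: the limit of > 10000 nM in this assay, at which 1 of the 4 values shown sits.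

Two substituents on this aromatic carbon give one step and no trend, so the compounds shown cannot say what in the change from fluoro to cyano lies behind the weaker inhibition. On these data alone, how a plain hydrogen, a methoxy group, a chlorine or an amine on the same carbon would read remains open, and so does whether the same swap would have a similar effect on a different group at the chain carbon.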